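This account rests on a few compounds, and the source may have more. Where it says the series, first, only, none or still open, it means among the compounds named here.

The measured compounds:
compound 1 `CC(C)(C)c1ccc(C/N=C(\S)NCc2ccc([N+](=O)[O-])cc2)cc1` — > 30000 nM
compound 2 `CC(C)(C)c1ccc(C/N=C(\S)NCc2ccc(NC(=N)S)cc2)cc1` — > 30000 nM

In a functional assay for antagonist activity at Vanilloid receptor (Rattus norvegicus), tested at 30 uM (on this read-out lower numbers stand for stronger inhibition and higher numbers for weaker inhibition), compound 1 gives > 30000 nM, which is a limit of the assay and not a number. In this assay compound 2 likewise gives > 30000 nM, again a limit rather than a number. Within the data shown here, the only measured step, a step that the two limits leave unreadable from compound 1 to compound 2, is therefore of unreadable size, and the sole evidence that bears on it is the limit of > 30000 nM in this assay, at which 2 of the 2 values shown sit. Compound 2 thus stands at a limit, with no numbered value anywhere in the set to anchor it.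

Compound 3 `CC(C)(C)c1ccc(C/N=C(\S)NCc2ccc(NS(=O)(=O)c3cccs3)cc2)cc1` is not yet measured. It differs from compound 2 by a group of 8 heavy atoms (4 carbon, 2 oxygen, 2 sulfur; one five-membered aromatic ring with 1 hetero atom) in place of a group of 3 heavy atoms (1 carbon, 1 nitrogen, 1 sulfur; no ring), on a nitrogen on an aromatic ring. Among the measured compounds shown here, no measured step involves the entering group, and the one measured step cannot be read, so the change gives no readable precedent in either direction. The step from compound 2 to compound 3 is therefore expected to be an at least 1.5-fold lower number from compound 2 to compound 3 (0.17 log units; that floor lies within the scatter), an estimate that rests on the limit alone. Compound 3 is accordingly estimated at 20000 nM in this assay, in a range from 3000 nM to 60000 nM, with a real chance that only a limit is again reported.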

Compound 3, half-maximal inhibitory concentration: > 30000 nM
Compound 3: only a limit was reported (the forecaster's own chance of this, stated with the estimate: 55%); middle value at least 1.5-fold (0.17 log units) from the limit.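

In this assay compound 3 gives > 30000 nM, a limit of the assay and not a number. Among these compounds, the steps from compound 1 and compound 2 to compound 3 therefore cannot be read, and the only evidence is this: the limit of > 30000 nM in this assay, at which 3 of the 3 values shown sit. The compounds shown leave open whether the (thiophen-2-yl)sulfonyl group changes inhibition at all, and in which direction.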